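The source may hold more compounds than are shown below. What is called first, only, known or untested is meant among the compounds shown, and "the series" means these compounds.

Measured so far in a functional assay on SK-MEL-28 cells (Homo sapiens) for cytotoxicity, read by CCK-8 assay, with a stated time of 24 h; a lower number here means a stronger inhibitor, a higher number a weaker inhibitor: compound 1 `COc1ccccc1Oc1c(N)nc(-c2cccc(Cl)c2)nc1Cl` gives 19400 nM; compound 2 `COc1ccccc1Oc1c(N)nc(-c2ccc(Cl)cc2)nc1Cl` gives 120 nM; compound 3 `COc1ccccc1Oc1c(N)nc(-c2cccc(Cl)c2)nc1OCCO` gives 4170 nM.

The two cores differ as 2-hydroxyethoxy in place of chloro on an aromatic carbon, which gave a 4.7-fold lower number from compound 1 to compound 3 (0.67 log units; beyond the scatter). Compound 4 `COc1ccccc1Oc1c(N)nc(-c2ccc(Cl)cc2)nc1OCCO` has not been run in this assay. It differs from compound 3 as 4-chlorophenyl in place of 3-chlorophenyl on an aromatic carbon. The same kind of change is seen from compound 1 to compound 2, (4-chlorophenyl in place of 3-chlorophenyl on an aromatic carbon), where the place is meta to a chloro group and para to a group of 9 heavy atoms, rather than meta to a 2-hydroxyethoxy group and para to a 2-methoxyphenoxy group; that change gave a 160-fold lower number from compound 1 to compound 2 (2.21 log units; beyond the scatter). A step of that kind is expected again, somewhat attenuated since it rests on one pair: a 120-fold lower number from compound 3 to compound 4 (2.08 log units; beyond the scatter). Compound 4 is estimated at 35 nM, with a likely range from 8 nM to 250 nM.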

Compound 4, half-maximal inhibitory concentration: > 80000 nM
Compound 4 gave a limit, no number; the forecaster's own chance of this, stated with the estimate: 0%; middle value at least 2200-fold (3.35 log units) from the limit.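

In this assay compound 4 gives > 80000 nM, a limit of the assay and not a number. The move from 3-chlorophenyl to 4-chlorophenyl does not carry from one core to the other, with an at least 19-fold higher number from compound 3 to compound 4 (1.28 log units; beyond the scatter) set against an earlier step in the opposite direction: the same change on two cores in this assay, a 160-fold lower number (2.21 log units; beyond the scatter) from compound 1 to compound 2 and an at least 19-fold higher number (1.28 log units; beyond the scatter) from compound 3 to compound 4, at least 3100-fold (3.49 log units) apart, beyond the scatter of two such steps. The change from chloro to 2-hydroxyethoxy does not carry either, with an at least 660-fold higher number from compound 2 to compound 4 (2.82 log units; beyond the scatter), so neither change can be transferred from a single pair, though these compounds give neither a cause nor an exact size for the reversal: the same change on two cores in this assay, a 4.7-fold lower number (0.67 log units; beyond the scatter) from compound 1 to compound 3 and an at least 660-fold higher number (2.82 log units; beyond the scatter) from compound 2 to compound 4, at least 3100-fold (3.49 log units) apart, beyond the scatter of two such steps.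

Going by these compounds, it remains open whether the reversal is tied to the 2-hydroxyethoxy group itself. A longer chain ending in hydroxyl, an amine or a carboxylic acid in its place, alongside 4-chlorophenyl, would test this.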